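Swapping a Large Group for Methylcarbamoyl

This account rests on a few compounds, and the source may have more. Where it says the series, first, only, none or still open, it means among the compounds named here.

Compound 1 `CC#C[C@H]1CN(S(=O)(=O)c2ccc(N)nc2)CCN1c1ccc(S(N)(=O)=O)cc1` gives 30 mL.min-1.g-1
Compound 2 `CC#CCC(O)(c1ccc(N2CCN(S(=O)(=O)c3ccc(N)nc3)C[C@@H]2C#CC)cc1)C(F)(F)F` gives 115 mL.min-1.g-1

Both values come from an ADME assay (liver) for metabolic stability, with Liver microsome (Rattus norvegicus) as the target, using microsomes and NADPH, with a stated time of 30 min (a lower number here means slower removal, a higher number faster removal of the compound), and compound 2 stands highest of the two. Compound 3 `CC#C[C@H]1CN(S(=O)(=O)c2ccc(N)nc2)CCN1c1ccc(C(=O)NC)cc1` carries methylcarbamoyl in place of the large group of compound 2, on an aromatic carbon: a group of 4 heavy atoms (2 carbon, 1 nitrogen, 1 oxygen; no ring) in place of a group of 10 heavy atoms (6 carbon, 1 oxygen, 3 fluorine; no ring), on an aromatic carbon. For the measured compounds named here, one measured step bears on this change: a 3.8-fold higher number from compound 1 to compound 2 (0.58 log units; beyond the scatter), beyond the scatter, where that same large group replaced a different group of 4 heavy atoms. Compound 3 also has a group of 4 heavy atoms there, so a drop of similar size is expected. The expected change is a 3.0-fold lower number from compound 2 to compound 3 (0.48 log units; beyond the scatter). The estimate for compound 3 is 38 mL.min-1.g-1, within a range from 16 mL.min-1.g-1 to 85 mL.min-1.g-1.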

Compound 3, intrinsic clearance in microsomes: 41 mL.min-1.g-1
For compound 3 the middle estimate is 1.1-fold (0.03 log units) below the measured one; low and high end bracket the measured number.
By their numbers in this assay, from the lowest: compounds 1 and 3 (each within the scatter of the next); then compound 2.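

In this assay, putting methylcarbamoyl in place of the large group gives a 2.8-fold lower number from compound 2 to compound 3 (0.45 log units; beyond the scatter), so on this aromatic carbon the higher number of compound 2 is lost with a second group of 4 heavy atoms, not only with sulfamoyl. Methylcarbamoyl in place of sulfamoyl gives a 1.4-fold higher number from compound 1 to compound 3 (0.14 log units; within the scatter), which does not separate these two groups in this assay. No measurement offered here explains either step.

Which part of the large group of compound 2 goes with its higher number remains open. So does how a carboxylic acid or an amine on this carbon would compare.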